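Adding a 2-Oxopropyl Group to a Diyne Alcohol

The source may report more compounds than this note shows. Statements on the series, on what has been measured and on what is new or still open speak of the compounds shown alone.

Compound 2 `CCCCCCCC#CC#CCO` is a straight-chain alcohol carrying two triple bonds. Going by the values given here, in a functional assay on SK-OV-3 cells (Homo sapiens) for cytotoxicity (on this read-out lower numbers stand for an effect already at smaller amounts and higher numbers for an effect only at larger amounts of compound), compound 2 gives 4.63 ug/mL, the highest of the two numbers seen so far, although the only other number lies within the scatter of it. Compound 1 `C=CCCCCCC#CC#CC(O)CC(C)=O` gives 3.85 ug/mL in this assay, so the two compounds cannot be told apart. Among the compounds with values here, no two measured compounds differ in a single place, so no measured step guides the next move. Compound 3 `CCCCCCCC#CC#CC(O)CC(C)=O` arises from compound 2 through the change (2-oxopropyl in place of hydrogen on a saturated chain carbon bound to an oxygen on a saturated carbon and a triple-bonded carbon). Compound 1, with 3.85 ug/mL in this assay, already carries a 2-oxopropyl group and sits alongside compound 2, which is the only hint available. The step of a 1.2-fold lower number from compound 2 to compound 3 (0.06 log units; within the scatter) is therefore expected to be small and not beyond the scatter. Compound 3 is estimated to give about 4 ug/mL, with a range from 1.5 ug/mL to 10 ug/mL.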

Compound 3, concentration for half-maximal effect: 1.81 ug/mL
The estimate for compound 3 lay 2.2-fold (0.34 log units) above the measured number; measured number inside the range.
By their numbers in this assay, from the lowest: compound 3; then compounds 1 and 2 (each within the scatter of the next).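

In this assay, placing 2-oxopropyl in place of hydrogen on a saturated chain carbon bound to an oxygen on a saturated carbon and a triple-bonded carbon gives a 2.6-fold lower number from compound 2 to compound 3 (0.41 log units; beyond the scatter), so this position responds to the change by more than the scatter. The other end of the chain also counts: ethyl in place of vinyl on a saturated chain carbon, five bonds along the chain from a triple-bonded carbon, gives a 2.1-fold lower number from compound 1 to compound 3 (0.33 log units; beyond the scatter), even though both compounds carry the 2-oxopropyl group. The lower number therefore goes with the 2-oxopropyl group and the ethyl-ended chain together, not with the 2-oxopropyl group alone.

Going by these compounds, whether an amine or a carboxylic acid in place of the 2-oxopropyl group would give a similar number remains open. No measurement at hand explains either step.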